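From Cyclopropyl to Cyclohexyl on the Shared Core

The source may hold more compounds than are shown below. What is called first, only, known or untested is meant among the compounds shown, and "the series" means these compounds.

Compound 1 `COC(=O)Cn1c(=O)c(S(=O)(=O)c2ccc(F)cc2F)cc2cnc(Nc3ccc4[nH]ccc4c3)nc21`: 5000 nM
Compound 2 `CCCn1c(=O)c(S(=O)(=O)c2ccc(F)cc2F)cc2cnc(Nc3ccc4[nH]ccc4c3)nc21`: 1000 nM
Compound 3 `O=c1c(S(=O)(=O)c2ccc(F)cc2F)cc2cnc(Nc3ccc4[nH]ccc4c3)nc2n1C1CC1`: 500 nM

In a functional assay on K562 cells (Homo sapiens) for inhibition, read by trypan blue exclusion, with a stated time of 72 h (on this read-out higher numbers stand for weaker inhibition and lower numbers for stronger inhibition), compound 3 gives 500 nM and shares the low end of the series with compound 2. The data show a 2.0-fold lower number from compound 2 to compound 3 (0.30 log units; within the scatter), and they also show a 10-fold lower number from compound 1 to compound 3 (1.00 log units; beyond the scatter). Compound 4 `O=c1c(S(=O)(=O)c2ccc(F)cc2F)cc2cnc(Nc3ccc4[nH]ccc4c3)nc2n1C1CCCCC1` carries cyclohexyl in place of cyclopropyl on an aromatic nitrogen. Going by the values given here, the closest precedent is a 2.0-fold lower number from compound 2 to compound 3 (0.30 log units; within the scatter), which exchanges propyl and cyclopropyl. The larger 10-fold lower number from compound 1 to compound 3 (1.00 log units; beyond the scatter) involves a methoxycarbonyl group that compound 4 lacks. Among the compounds with values here, no cyclohexyl compound has been measured, and no step beyond the scatter is expected in either direction. The expected change is no change at the digits printed from compound 3 to compound 4 (within the scatter). The estimated value for compound 4 is 500 nM, within an expected range from 120 nM to 2000 nM.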

Compound 4, half-maximal inhibitory concentration: 10000 nM
Compound 4: middle estimate off by 20-fold (1.30 log units), on the low side; the measured number lies above the stated range.
By their numbers in this assay, from the lowest: compounds 3 and 2 (each within the scatter of the next); then compounds 1 and 4 (each within the scatter of the next).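

In this assay, going by these compounds alone, the aromatic nitrogen proved sensitive to the size of its ring substituent: cyclohexyl in place of cyclopropyl gives a 20-fold higher number from compound 3 to compound 4 (1.30 log units; beyond the scatter), the first large step. Cyclohexyl in place of propyl also gives a 10-fold higher number from compound 2 to compound 4 (1.00 log units; beyond the scatter), so this position moves the number beyond the scatter without any methoxycarbonyl group, while the change from the ester side chain gives a 2.0-fold higher number from compound 1 to compound 4 (0.30 log units; within the scatter). No evidence here accounts for the cyclohexyl result. The compounds shown leave open how cyclobutyl or cyclopentyl would read at this nitrogen, and whether a cyclohexyl ring carrying an amine would read the same.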